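Adding a hydroxy to compound 2

The compounds below may be only part of what the source reports. "The series", "measured", "known", "first", "only" and "open" are said of these compounds alone.

In a functional assay on BGC-823 cells (Homo sapiens) for cytotoxicity, read by MTT assay (a lower number here means a stronger inhibitor, a higher number a weaker inhibitor), compound 1 (`CC(=O)C(C)CCCCc1cc(O)c(C)c(=O)o1`) gives > 200000 nM as a limit, not a number. Compound 2 (`CCC(C)CCCCc1cc(O)c(C)c(=O)o1`) gives > 200000 nM and this, too, is a limit. Compound 3 (`Cc1c(O)cc(CCCCC(C)[C@H](C)O)oc1=O`) has not yet been measured. It carries hydroxy in place of hydrogen on a saturated chain carbon bound to two saturated chain carbons. For the measured compounds named here, the one measured step that bears on this is a step that the two limits leave unreadable from compound 1 to compound 2 and it swaps acetyl for ethyl, so it offers no size to carry over. With only the limit of > 200000 nM in this assay, at which 2 of the 2 values shown sit, to go on, no step beyond the scatter is expected in this assay in either direction, and another limit is the likeliest result. The estimated step is a number no higher from compound 2 to compound 3 (the limit leaves the size open) with no clear direction. Compound 3 is expected near 200000 nM (estimated range 80000 nM to 400000 nM).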

Compound 3, half-maximal inhibitory concentration: > 200000 nM
Compound 3 was reported as a limit; the forecaster's own chance of this, stated with the estimate: 75%; the middle value sits exactly at the limit.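

No step among compound 1, compound 2 and compound 3 can be read, as all three stand at the same limit and none gives an actual number: the limit of > 200000 nM in this assay, at which 3 of the 3 values shown sit.

The compounds shown leave open whether hydroxy in place of hydrogen changes the result at all in this assay.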